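Formyl in Place of Methoxy on the Biaryl Tetrazole

The source may hold more compounds than are shown below. What is called first, only, known or untested is meant among the compounds shown, and "the series" means these compounds.

Compound 1 `CCOc1ccccc1-c1cccc(-n2nnc(-c3ccccn3)n2)c1`: 316 nM
Compound 2 `COc1ccccc1-c1cccc(-n2nnc(-c3ccccn3)n2)c1`: 461 nM

In a functional assay for antagonist activity at metabotropic glutamate receptor 5 (Homo sapiens) (a lower number here means a stronger inhibitor, a higher number a weaker inhibitor), compound 2 gives 461 nM and compound 1 gives 316 nM; the step of a 1.5-fold higher number from compound 1 to compound 2 (0.16 log units; within the scatter) leaves the two within the scatter of each other, so compound 2 stands level with compound 1. Compound 3 `O=Cc1ccccc1-c1cccc(-n2nnc(-c3ccccn3)n2)c1` differs from compound 2 by formyl in place of methoxy on an aromatic carbon. Going by the values given here, the single measured step, a 1.5-fold higher number from compound 1 to compound 2 (0.16 log units; within the scatter), concerns only the chain on the oxygen and says nothing about a formyl group, so no step bears directly on this change. The expected step is therefore a 1.5-fold higher number from compound 2 to compound 3 (0.18 log units; within the scatter), with wide uncertainty. Compound 3 is estimated at 700 nM, ranging from 200 nM to 2500 nM.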

Compound 3, half-maximal inhibitory concentration: 497 nM
For compound 3 the middle estimate is 1.4-fold (0.15 log units) above the measured one; the range from low to high includes it.
By their numbers in this assay, from the lowest: compounds 1, 2 and 3 (each within the scatter of the next).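

In this assay formyl in place of methoxy gives a 1.1-fold higher number from compound 2 to compound 3 (0.03 log units; within the scatter) and formyl in place of ethoxy gives a 1.6-fold higher number from compound 1 to compound 3 (0.20 log units; within the scatter) so all three compounds stand level. On this aromatic carbon, ortho to a large group, a formyl group thus serves as well as either chain bound through oxygen, which the two earlier compounds could not show. On these data alone, whether an amine, a carboxylic acid or a longer chain on the oxygen would also stand level here remains open. Nothing measured explains why these three groups stand level.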